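Shrinking a hydroxamic acid's second substituent to a methyl

The source may hold more compounds than are shown below. What is called first, only, known or untested is meant among the compounds shown, and "the series" means these compounds.

Compound 1 `O=C(NO)c1cccc(C(=O)NCc2ccccc2)c1` in an assay on isolated protein for inhibition of histone deacetylase 4 (Homo sapiens), read by fluorescence, with a stated time of 60 min; a higher number here means a weaker inhibitor, a lower number a stronger inhibitor: a limit, > 33000 nM
Compound 2 `CNC(=O)c1cccc(C(=O)NO)c1` in this assay: a limit, > 33000 nM

Compound 2 gives in this assay only a limit, > 33000 nM. The step that the two limits leave unreadable from compound 1 to compound 2 cannot be read because both values sit at the limit of > 33000 nM in this assay, at which 2 of the 2 values shown sit. Compound 3 `Cc1cccc(C(=O)NO)c1` carries methyl in place of methylcarbamoyl on an aromatic carbon. No readable measured step bears on this change, so no direction can be drawn from the data. Compound 3 is therefore expected to remain near the same limit, with an expected step that the limit leaves unreadable from compound 2 to compound 3. Compound 3 is estimated at 45000 nM, ranging from 15000 nM to 150000 nM.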

Compound 3, half-maximal inhibitory concentration: > 33000 nM
Compound 3: only a limit was reported; the forecaster's own chance of this, stated with the estimate: 85%; the middle value does not contradict the limit.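

Within the data shown here, no step from compound 2 to compound 3 can be read in this assay, since compound 3 also gives only a limit: the limit of > 33000 nM in this assay, at which 3 of the 3 values shown sit. The compounds shown leave open how compound 1, compound 2 and compound 3 actually rank.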